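This account rests on a few compounds, and the source may have more. Where it says the series, first, only, none or still open, it means among the compounds named here.

Working notes on the series. The three measured compounds share one core with a varied substituent on the aromatic oxygen. In a functional assay on mitochondria (Cricetulus griseus) for inhibition of Monoamine oxidase (Homo sapiens), tested at 0.9 uM (a lower number here means a weaker effect, a higher number a stronger effect of the compound at the concentration tested), compound 1 `O=c1c(-c2ccc(O)cc2)coc2cc(CC3OC(CO)C(O)C(O)C3O)ccc12` gives 0%, compound 2 `O=c1c(-c2ccc(O)cc2)coc2cc(OCCCCCCBr)ccc12` gives 71.2%, and compound 3 `O=c1c(-c2ccc(O)cc2)coc2cc(OCCCCBr)ccc12` gives 55.3%. On these three numbers compound 3 stands second highest: compound 2 lies above it, compound 1 far below it, with both gaps beyond the scatter.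

Compound 4 `O=c1c(-c2ccc(O)cc2)coc2cc(OCCCBr)ccc12` has not yet been measured in this assay. It differs from compound 3 by bromo in place of bromomethyl on a saturated chain carbon, three bonds along the chain from an oxygen on an aromatic ring.

Among the measured compounds shown here, only one measured step bears on this change: a number 15.9 percentage points lower from compound 2 to compound 3 (beyond the scatter). That step is the same kind of shortening of the bromine-terminated chain on the aromatic oxygen, one cut further out, and it gave a modest loss. Compound 1 does not carry a bromine-terminated chain and gives no guidance on chain length. With a single step of this kind, the expectation is that shortening the chain once more will again lower the inhibition by a modest amount, roughly in line with that step, though a step within the scatter cannot be excluded. For compound 4 the expected step is therefore a number 13.3 percentage points lower from compound 3 to compound 4 (beyond the scatter), a decrease. Compound 4 is thus estimated at 42% in this assay, with a range from 25% to 60%.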

Compound 4, a percentage reported as inhibition, at one concentration (the size of the read-out at that concentration, not a potency): 67.7%
Compound 4: the middle estimate sits 25.7 percentage points below what was measured; the measured number lies above the stated range.
By their numbers in this assay, from the lowest: compound 1; then compound 3; then compounds 4 and 2 (each within the scatter of the next).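

In this assay, the change from 4-bromobutyl to 3-bromopropyl gives a number 12.4 percentage points higher from compound 3 to compound 4 (beyond the scatter), which runs against the earlier a number 15.9 percentage points lower from compound 2 to compound 3 (beyond the scatter), so shortening the bromine-terminated chain does not move the inhibition in one direction across these compounds. The third step, a number 3.5 percentage points lower from compound 2 to compound 4 (within the scatter), puts the two ends of this short chain series level, and compound 3 alone forms a dip among the three bromine-terminated compounds, with steps beyond the scatter on both sides. Nothing available on these compounds accounts for this dip.

Going by these compounds, what remains open is how the read-out behaves beyond this range, with a 2-bromoethyl chain at the short end or a still longer chain at the other, and so whether the dip at compound 3 belongs to a wider pattern. On these data alone, it is also open whether the terminal bromine matters at all, which an amine, a hydroxyl or a carboxylic acid at the end of the 3-bromopropyl chain in place of bromine would test directly.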